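Trimming the Amide on Compound 2

The source may hold more compounds than are shown below. What is called first, only, known or untested is meant among the compounds shown, and "the series" means these compounds.

Measured in an ADME assay (liver) for metabolic stability, with Liver microsome (Homo sapiens) as the target, using microsomes; a higher number here means faster removal of the compound, a lower number slower removal:
- Compound 1 `Cc1ccc(Oc2cc(C(=O)Nc3cnc(C)cn3)cc3oc(C)cc23)cc1`: 47 mL/min/kg
- Compound 2 `Cc1cc2c(Oc3cnc(C(=O)N4CC(C)(C)C4)cn3)cc(C(=O)Nc3cnccn3)cc2o1`: 21.2 mL/min/kg

In this assay compound 1 gives 47 mL/min/kg and compound 2 gives 21.2 mL/min/kg, the lower of the two numbers. The gap between these two compounds lies beyond the scatter. Compound 3 `Cc1cc2c(Oc3cnc(C(=O)N(C)C)cn3)cc(C(=O)Nc3cnccn3)cc2o1` carries dimethylamino in place of 3,3-dimethylazetidin-1-yl on a carbonyl carbon. Going by the values given here, no measured pair shows this change, so the expectation rests on the structural change alone: no step beyond the scatter is expected in this assay. The estimated step is a 1.2-fold lower number from compound 2 to compound 3 (0.07 log units; within the scatter). For compound 3 the expected clearance is 18 mL/min/kg, with an estimated range of 10 mL/min/kg to 33 mL/min/kg.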

Compound 3, clearance: 15 mL/min/kg
Compound 3: middle estimate off by 1.2-fold (0.08 log units), on the high side; the measured number falls inside the stated range.
By their numbers in this assay, from the lowest: compounds 3 and 2 (each within the scatter of the next); then compound 1.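

In this assay, dimethylamino in place of 3,3-dimethylazetidin-1-yl on a carbonyl carbon gives a 1.4-fold lower number from compound 2 to compound 3 (0.15 log units; within the scatter). This first one-place comparison at this position shows that the four-membered ring can be exchanged for an open dimethylamino group without the two compounds separating in this read-out. The compounds shown leave open whether methylamino, a plain amino group or a morpholine ring on the same carbonyl carbon would give a step beyond the scatter. Nothing at hand accounts for the result.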